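A few compounds are considered here, and "the series" means these few. Any claim that something is new, unique, unknown or untested is made for them only; others in the source may bear on it.

Measured so far:
- compound 1, `COc1cc2c(cc1OC)C(CC(=O)NC1CCCC1)CC2`, gives 40.7% in a functional assay on the whole organism (strain Wistar) for inhibition, with Rattus norvegicus as the target, read by paw edema, with stated times of 60 min and 6 h, at a dose of 100 mg/kg by the oral route; on this read-out lower numbers stand for less inhibition and higher numbers for more inhibition at the one dose given (going by the name of the read-out)
- compound 2, `COc1cc2c(cc1OC)C(CC(=O)NC1CCCCC1)CC2`, gives 48.2% in this assay

Compound 2 holds the higher of the two numbers, yet the gap to compound 1 is within the scatter, so nothing can be said about an order between them. Within the data shown here, the one measured step, a number 7.5 percentage points higher from compound 1 to compound 2 (within the scatter), concerns the ring on the amide-type nitrogen and stays within the scatter.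

Compound 3, `COc1cc2c(cc1OC)C(CC(=O)N1CCOCC1)CC2`, is not yet measured. It differs from compound 2 in one place: morpholin-4-yl in place of cyclohexylamino on a carbonyl carbon. Among the measured compounds shown here, the measured step between compound 1 and compound 2 exchanged one carbon ring for another on the same nitrogen and left the number essentially unchanged; it does not test a change in which the hydrogen on the nitrogen is lost and an oxygen enters the ring, so no measured step bears directly on the move to compound 3.

With that in mind, the expectation for compound 3 in this assay is a step of a number 8.2 percentage points lower from compound 2 to compound 3 (within the scatter), which would not be beyond the scatter. Compound 3 is therefore estimated at 40%, with a range from 20% to 60%.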

Compound 3, a percentage reported as inhibition, in the whole organism at one dose (the size of the read-out at that dose, not a potency): 14.8%
For compound 3 the middle estimate is 25.2 percentage points above the measured one, outside the stated range (below it).
By their numbers in this assay, from the lowest: compound 3; then compounds 1 and 2 (each within the scatter of the next).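

The group on the carbonyl carbon can clearly move the number in this assay: the earlier swap of one carbon ring for another gave no readable change, whereas morpholin-4-yl in place of cyclohexylamino gives a number 33.4 percentage points lower from compound 2 to compound 3 (beyond the scatter), and in place of cyclopentylamino it gives a number 25.9 percentage points lower from compound 1 to compound 3 (beyond the scatter). This change is not a single edit, since the amide hydrogen, a hydrogen-bond donor, is lost, and an oxygen enters the ring as a hydrogen-bond acceptor. No supporting data are available to explain the lower number.

The compounds shown do not separate these two changes: piperidin-1-yl on the same carbonyl carbon would lack both the amide hydrogen and the ring oxygen, while tetrahydropyran-4-ylamino would keep the amide hydrogen and carry an oxygen in its ring. From the compounds shown here alone, it also remains open whether an open-chain group such as diethylamino, which has no ring and no amide hydrogen, would give a number close to that of compound 3 or closer to those of the two compounds with carbon rings.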